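The source may report more compounds than this note shows. Statements on the series, on what has been measured and on what is new or still open speak of the compounds shown alone.

Of the compounds shown here, three built on one shared core have been measured in a functional assay on U-87MG ATCC cells for antiproliferative activity against U-87 MG (Homo sapiens), read by MTT assay, with a stated time of 48 h, tested at 5 uM; on this read-out lower numbers stand for a stronger effect and higher numbers for a weaker effect at the one concentration tested. Compound 1 `Cc1nc(-c2ccccc2)sc1C(=O)CSc1nc(-c2ccccc2)c(C#N)c(=O)[nH]1` gives 92.1%, the highest of the three numbers. Compound 3 `Cc1nc(-c2ccccc2)sc1C(=O)CSc1nc(-c2ccc(Cl)cc2)c(C#N)c(=O)[nH]1` gives 90.9%, and the step of a number 1.2 percentage points lower from compound 1 to compound 3 (within the scatter) stays within the scatter. Compound 2 `COc1ccc(-c2nc(SCC(=O)c3sc(-c4ccccc4)nc3C)[nH]c(=O)c2C#N)cc1OC` gives 80.8%; the step of a number 11.3 percentage points lower from compound 1 to compound 2 (beyond the scatter) is the only one beyond the scatter.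

Compound 4 `COc1ccc(-c2nc(C)c(C(=O)CSc3nc(-c4ccccc4)c(C#N)c(=O)[nH]3)s2)cc1` has not yet been measured. It differs from compound 1 by a single change, (methoxy in place of hydrogen on an aromatic carbon), placed para to a large group. Going by the values given here, no measured step touches this same ring; the two known changes, chloro and 3,4-dimethoxyphenyl, belong to the other phenyl. The chloro step a number 1.2 percentage points lower from compound 1 to compound 3 (within the scatter) moved nothing beyond the scatter, while the larger dimethoxy step a number 11.3 percentage points lower from compound 1 to compound 2 (beyond the scatter) produced a modest drop. A single methoxy entering is expected to behave more like the small change, so the expected step of a number 4.1 percentage points lower from compound 1 to compound 4 (within the scatter) is none beyond the scatter. Compound 4 is therefore estimated at 88% in this assay, with a range from 76% to 98%.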

Compound 4, a percentage reported as activity, at one concentration (the size of the read-out at that concentration, not a potency): 99%
Compound 4: the middle estimate sits 11 percentage points below what was measured; measured number above the stated range.
By their numbers in this assay, from the lowest: compound 2; then compounds 3, 1 and 4 (each within the scatter of the next).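

The phenyl to 4-methoxyphenyl change is the only change shown on this ring, and in this assay it gives a number 6.9 percentage points higher from compound 1 to compound 4 (within the scatter). Going by these compounds alone, a methoxy para to a large group on this ring therefore leaves the read-out at one concentration indistinguishable from that of compound 1, whereas compound 2, changed on the other phenyl, is the only compound with a step from compound 1 beyond the scatter. No available measurement bears on why this methoxy has so little effect, so no cause can be given.

From the compounds shown here alone, whether an amine, a carboxylic acid or a longer chain in place of this methoxy would produce a step beyond the scatter remains open. Also open is how a methoxy elsewhere on this ring would read, and a single concentration gives no measure of potency for any of these compounds.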